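This account rests on a few compounds, and the source may have more. Where it says the series, first, only, none or still open, it means among the compounds named here.

Compound 1 `Cc1ccc(C(=O)NCc2ccc(CNS(=O)(=O)c3ccc(C)cc3)cc2)cc1` and compound 2 `Cc1ccc(S(=O)(=O)NCc2ccc(CNC(=O)c3c(Cl)cc(Cl)cc3Cl)cc2)cc1` share a core and differ only in the aryl group on the carbonyl carbon. In an assay on MDA-MB-231 cells for binding affinity to C-X-C chemokine receptor type 4 (Homo sapiens), read by immunofluorescence and microscopy, with stated times of 10 min and 30 min (a higher number here means that more compound is needed for the effect, a lower number that less compound is needed), compound 1 gives 1000 nM, while compound 2 gives 10 nM. Among the compounds with values here, the step of a 100-fold lower number from compound 1 to compound 2 (2.00 log units; beyond the scatter) is the only measured step and it is large. Compound 2 therefore stands lowest of the two measured values in this assay, with compound 1 the nearest neighbour at a much higher number.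

Compound 3 `Cc1ccc(S(=O)(=O)NCc2ccc(CNC(=O)c3ccccc3F)cc2)cc1` changes the same position once more: 2-fluorophenyl in place of 2,4,6-trichlorophenyl on a carbonyl carbon. Within the data shown here, the single measured step bears on this change only indirectly, since it shows how strongly this assay responds to what sits on the carbonyl carbon, but it does not show what a single fluorine does there. The 2-fluorophenyl group is much nearer to the 4-methylphenyl of compound 1 in what it carries than to the trichlorophenyl of compound 2, so a rise in the number is expected, though of smaller size than the measured step. The estimated step of a 30-fold higher number from compound 2 to compound 3 (1.48 log units; beyond the scatter) is expected for compound 3. Compound 3 is thus estimated at 300 nM, with a range from 60 nM to 2000 nM.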

Compound 3, effective concentration (reported as EC, without a stated level of effect): 1000 nM
Compound 3: middle estimate off by 3.3-fold (0.52 log units), on the low side, within the range that was stated.
By their numbers in this assay, from the lowest: compound 2; then compounds 1 and 3 (each within the scatter of the next).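

In this assay, the change on the carbonyl carbon gives a 100-fold higher number from compound 2 to compound 3 (2.00 log units; beyond the scatter), a step of the same printed size as the one first seen between the 4-methylphenyl and 2,4,6-trichlorophenyl groups. The new comparison with 4-methylphenyl gives no change at the digits printed from compound 1 to compound 3 (within the scatter), so 2-fluorophenyl and 4-methylphenyl cannot be told apart at this position, and among these three compounds only the 2,4,6-trichlorophenyl of compound 2 stands apart. Nothing available bears on why this one group differs from the other two.

Going by these compounds, it remains open whether a dichlorophenyl or a trimethylphenyl on the carbonyl carbon would give a number like that of compound 2 or like those of compound 1 and compound 3, and so whether the low number needs all that the 2,4,6-trichlorophenyl group carries. Also open, on these data alone, is what a pyridine ring or a phenyl bearing an amine or a carboxylic acid would do at this place, and whether the step would hold if the rest of the shared core were changed.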